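Hydrazone variation on a chloropyrimidine core against colon cancer cells

The source may report more compounds than this note shows. Statements on the series, on what has been measured and on what is new or still open speak of the compounds shown alone.

Measured compounds:
- compound 1, `Nc1cccc(Nc2nc(N/N=C/c3ccc(F)cc3)ncc2Cl)c1`, 12300 nM
- compound 2, `C=CC(=O)Nc1cccc(Nc2nc(N/N=C/c3cn(Cc4ccccc4)c4ccccc34)ncc2Cl)c1`, 11000 nM
- compound 3, `COc1ccc(/C=N/Nc2ncc(Cl)c(Nc3cccc(NC(=O)/C=C/CN(C)C)c3)n2)cc1`, 4820 nM

In an ADME assay on HT-29 cells (Homo sapiens) for inhibition, read by MTT assay, with a stated time of 72 h (a lower number here means a stronger inhibitor, a higher number a weaker inhibitor), compound 3 gives the lowest number of the three. Compound 2 gives 11000 nM, a higher number, beyond the usual scatter. Compound 1 gives 12300 nM, also clearly higher than compound 3. The three compounds differ in several places at once, so no single change can be tied to any one shift in the numbers.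

Compound 4, `COc1cccc(/C(C)=N/Nc2ncc(Cl)c(Nc3cccc(NC(=O)/C=C/CN(C)C)c3)n2)c1`, has not yet been measured. It differs from compound 3 in one place: a group of 11 heavy atoms (9 carbon, 1 nitrogen, 1 oxygen; one six-membered aromatic ring of carbon only) in place of a group of 10 heavy atoms (8 carbon, 1 nitrogen, 1 oxygen; one six-membered aromatic ring of carbon only), on a nitrogen on an aromatic ring. Among the measured compounds shown here, no pair of measured compounds shows the effect of a change of this kind, so there is no direct guide for the size of the step.

Given that gap, compound 4 is expected to land close to compound 3, with the step of a 1.2-fold higher number from compound 3 to compound 4 (0.10 log units; within the scatter) most likely no larger than the usual scatter, in either direction. Compound 4 is therefore estimated at 6000 nM in this assay, within a range from 2500 nM to 15000 nM.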

Compound 4, half-maximal inhibitory concentration: 3870 nM
The estimate for compound 4 lay 1.6-fold (0.19 log units) above the measured number; measured number inside the range.
By their numbers in this assay, from the lowest: compounds 4 and 3 (each within the scatter of the next); then compounds 2 and 1 (each within the scatter of the next).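

Among the compounds shown here, the first comparison here that changes only one place gives, in this assay, a 1.2-fold lower number from compound 3 to compound 4 (0.10 log units; within the scatter) and so shows no real shift. On a nitrogen on an aromatic ring, a group of 11 heavy atoms can therefore replace a group of 10 heavy atoms, each with one six-membered aromatic ring of carbon only, without a change that can be told apart from the ordinary variation between repeated measurements. No measurement shown here bears on why the number holds steady in this swap.

This single swap replaces the whole group, so it cannot separate the added carbon from any other difference between the two groups, and it cannot show whether a group carrying an amine or a carboxylic acid, or a longer chain, would be accepted at this nitrogen as well. Going by these compounds, the part played by the dimethylamino chain shared by compound 3 and compound 4 also stays open, since compound 1 and compound 2 differ from them in several places at once.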